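Hydroxy to methoxy on compound 1

A few compounds are considered here, and "the series" means these few. Any claim that something is new, unique, unknown or untested is made for them only; others in the source may bear on it.

Compound 1 (`C=C1CC[C@H]2C(C)(C)CCC[C@]2(C)[C@H]1CC/C(C)=C/Cc1c(O)cc(O)c2c(=O)c(O)c(-c3ccc(O)cc3)oc12`) gives 30000 nM in a functional assay on HeLa cells (Homo sapiens) for cytotoxicity, read by XTT assay, with a stated time of 72 h; on this read-out lower numbers stand for stronger inhibition and higher numbers for weaker inhibition
Compound 2 (`CC(=O)c1c(O)cc(O)c(CC=C(C)C)c1O`) gives 30000 nM in this assay

On these numbers compound 1 stands level with compound 2, and the two values lie within the usual scatter of each other. Within the data shown here, only these two compounds have been measured so far, and they offer no step between close relatives to serve as a guide.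

The next compound is compound 3 (`C=C1CC[C@H]2C(C)(C)CCC[C@]2(C)[C@H]1CC/C(C)=C/Cc1c(O)cc(O)c2c(=O)c(O)c(-c3ccc(OC)cc3)oc12`), which has not yet been measured in this assay and differs from compound 1 in one place. The difference is methyl in place of hydrogen on an oxygen on an aromatic ring, turning 4-hydroxyphenyl into 4-methoxyphenyl. The rest of the structure stays the same.

Among the measured compounds shown here, the data contain no measured example of this change, so no step beyond the scatter is expected in either direction, and the starting point remains compound 1 at 30000 nM as measured. The estimated change is a 1.2-fold lower number from compound 1 to compound 3 (0.08 log units; within the scatter) as the expected step. For compound 3 the expected value is 25000 nM, with an estimated range from 10000 nM to 60000 nM.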

Compound 3, half-maximal inhibitory concentration: > 100000 nM
Compound 3: a limit, no number; the forecaster's own chance of this, stated with the estimate: 30%; middle value at least 4.0-fold (0.60 log units) from the limit.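

In this assay compound 3 gives > 100000 nM, which is a limit and not a number. Turning 4-hydroxyphenyl into 4-methoxyphenyl, with methyl in place of hydrogen on an oxygen on an aromatic ring, gives the first readable step between close relatives in this set, an at least 3.3-fold higher number from compound 1 to compound 3 (0.52 log units; beyond the scatter), and this step lies beyond the scatter, so the read-out is not indifferent to this change at this position and inhibition is weaker with the methyl present. The step gives only a lower bound on the size of the change, since compound 3 sits at a limit: the limit of > 100000 nM in this assay, at which 1 of the 3 values shown sits.

From the compounds shown here alone, with a single pair, it remains open whether the higher number goes with the loss of the hydrogen or with the methyl that enters, and what an ethyl on the same oxygen, or an amine or a fluorine in place of the hydroxy, would give. Going by these compounds, it also remains open whether the same methyl on one of the other hydroxy groups of the shared core would shift the number in the same way.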